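The source may report more compounds than this note shows. Statements on the series, on what has been measured and on what is new or still open speak of the compounds shown alone.

The compounds here share one core and were examined for how much of each is tolerated. Compound 1, `O=C(/C=C/c1ccc([N+](=O)[O-])o1)c1ccc(C2CCCCC2)cc1`, and compound 2, `CC(C)(C)c1ccc(C(=O)/C=C/c2ccc([N+](=O)[O-])s2)cc1`, were both run in an ADME assay on Vero cells (Chlorocebus sabaeus) for cytotoxicity, read by resazurin assay, with a stated time of 72 h; a higher number here means that more compound is tolerated, a lower number that less compound is tolerated. For compound 1 the result is a limit of the assay, > 100000 nM. For compound 2 the result is likewise a limit of the assay, > 100000 nM. Both therefore sit at the limit of > 100000 nM in this assay, at which 2 of the 3 values shown sit. Compound 3, `O=C(/C=C/c1ccc([N+](=O)[O-])s1)c1ccc(C2CCCCC2)cc1`, has no reported result in this assay, recorded only as "not determined" (no result reported). Where compound 3 stands can therefore be told solely from the two neighbouring results, which are limits of the assay rather than numbers. Compound 4, `CCCCc1ccc(C(=O)/C=C/c2ccc([N+](=O)[O-])s2)cc1`, is the next step from compound 3: butyl in place of cyclohexyl on an aromatic carbon. No measured pair in this set isolates such a change, so the numbers shown give no size for this step in this assay in either direction, and the working assumption is a step that does not exceed the usual scatter. With both measured analogues at the limit, the expectation for compound 4 in this assay is a result that does not differ from those two beyond the usual scatter. Compound 4 is thus estimated at 100000 nM, within 40000 nM to 300000 nM, and is expected most likely to be reported once more only as a limit.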

Compound 4, half-maximal cytotoxic concentration: 81300 nM
Compound 4: the middle estimate sits 1.2-fold (0.09 log units) above what was measured; low and high end bracket the measured number.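

Among these compounds, with compound 4, this assay gives for the first time in this set a number rather than a limit, and that makes a change at this position readable at all. Butyl in place of tert-butyl on the aromatic carbon gives an at least 1.2-fold lower number from compound 2 to compound 4 (0.08 log units; that floor lies within the scatter), so what can be stated of this change does not go beyond the scatter, and a true shift of any larger size is neither shown nor excluded. The result for compound 2 is a limit of the assay, and the real size of the step stays unknown because it starts from that limit: the limit of > 100000 nM in this assay, at which 2 of the 4 values shown sit.

The step from cyclohexyl to butyl cannot be read, as compound 3 has no reported result to set against compound 4, so the two groups remain uncompared at this position. Going by these compounds, whether a longer chain, an amine or a carboxylic acid in place of butyl on that aromatic carbon would move the number clearly beyond the scatter also stays open.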